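A few compounds are considered here, and "the series" means these few. Any claim that something is new, unique, unknown or untested is made for them only; others in the source may bear on it.

Measured so far:
compound 1 `COc1ccc(CN(C(=O)CSC2=CN=NC2C)c2cc(OC)c(OC)c(OC)c2)cc1` — 45000 nM
compound 2 `COc1ccc(CN(C(=O)CSc2nnnn2C)c2cc(OC)c(OC)c(OC)c2)cc1` — 10500 nM

In a functional assay on PC-3 cells (Homo sapiens) for antiproliferative activity, read by MTT assay, with a stated time of 48 h (on this read-out lower numbers stand for stronger inhibition and higher numbers for weaker inhibition), compound 1 gives the highest number of the two; the nearest is compound 2, reached by a 4.3-fold lower number from compound 1 to compound 2 (0.63 log units; beyond the scatter). Compound 3 `COc1ccc(CN(C(=O)CSc2nc3ccccc3o2)c2cc(OC)c(OC)c(OC)c2)cc1` is not yet measured. It differs from compound 1 by a group of 9 heavy atoms (7 carbon, 1 nitrogen, 1 oxygen; one five-membered aromatic ring with 2 hetero atoms, one six-membered aromatic ring of carbon only) in place of a group of 6 heavy atoms (4 carbon, 2 nitrogen; one five-membered non-aromatic ring with 2 hetero atoms), on a sulfur. Among the compounds with values here, the only step that bears on this change is a 4.3-fold lower number from compound 1 to compound 2 (0.63 log units; beyond the scatter), which also replaces the same group on the sulfur and went modestly lower. A lowering of similar or smaller size is therefore expected, a 3.0-fold lower number from compound 1 to compound 3 (0.48 log units; beyond the scatter). Compound 3 is estimated at 15000 nM, with a range from 4000 nM to 60000 nM.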

Compound 3, half-maximal inhibitory concentration: 3530 nM
The estimate for compound 3 lay 4.2-fold (0.63 log units) above the measured number; the measured number lies below the stated range.
By their numbers in this assay, from the lowest: compound 3; then compound 2; then compound 1.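

In this assay, the group on this sulfur can shift the number further than the first step showed: 1,3-benzoxazol-2-yl gives a 13-fold lower number from compound 1 to compound 3 (1.11 log units; beyond the scatter), and against 1-methyl-1H-tetrazol-5-yl it gives a 3.0-fold lower number from compound 2 to compound 3 (0.47 log units; beyond the scatter). A two-ring aromatic group is therefore accepted on this sulfur, and the two aromatic groups differ beyond the scatter. Nothing measured accounts for this order of the three groups.

On these data alone, it remains open whether the ring oxygen or the six-membered carbon ring of 1,3-benzoxazol-2-yl matters more. A 1,3-benzothiazol-2-yl or a plain phenyl on the same sulfur would help separate the two.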